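The source may hold more compounds than are shown below. What is called first, only, known or untested is meant among the compounds shown, and "the series" means these compounds.

Measured compounds:
compound 1 `N#CC1=C(N)Oc2c(N)cc3nc4ccccc4nc3c2C12C(=O)N(Cc1cnnn1-c1cccc(Br)c1)c1ccccc12` — > 50000 nM
compound 2 `Cc1cc(C)cc(-n2nncc2CN2C(=O)C3(C(C#N)=C(N)Oc4c(N)cc5nc6ccccc6nc5c43)c3ccccc32)c1` — > 50000 nM

In a functional assay on MCF7 cells (Homo sapiens) for antiproliferative activity, read by MTT assay, with a stated time of 48 h (a higher number here means a weaker inhibitor, a lower number a stronger inhibitor), compound 1 reaches only the limit > 50000 nM. Compound 2 likewise sits at the limit > 50000 nM. Among the compounds with values here, the one measured step, a step that the two limits leave unreadable from compound 1 to compound 2, is therefore unreadable, since both values rest on (the limit of > 50000 nM in this assay, at which 2 of the 2 values shown sit). Compound 3 `N#CC1=C(N)Oc2c(N)cc3nc4ccccc4nc3c2C12C(=O)N(Cc1cnnn1-c1c(Cl)cc(Cl)cc1Cl)c1ccccc12` carries 2,4,6-trichlorophenyl in place of 3,5-dimethylphenyl on an aromatic nitrogen. Within the data shown here, no measured step speaks to this change beyond the two limits, so no shift beyond the scatter is expected in this assay. Compound 3 is expected to give 70000 nM, within 20000 nM to 300000 nM, most probably again as a limit. The expected step is a step that the limit leaves unreadable from compound 2 to compound 3.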

Compound 3, half-maximal inhibitory concentration: 37800 nM
Compound 3: the middle estimate sits 1.9-fold (0.27 log units) above what was measured; low and high end bracket the measured number.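

In this assay, compound 3, with 2,4,6-trichlorophenyl on the aromatic nitrogen, is the only one of the three to give a number, 37800 nM, so this position can now be read on a scale. The change amounts to an at least 1.3-fold lower number from compound 2 to compound 3 (0.12 log units; that floor lies within the scatter), and to an at least 1.3-fold lower number from compound 1 to compound 3 (0.12 log units; that floor lies within the scatter), so it is not shown to exceed the scatter. The step between compound 1 and compound 2 still cannot be read: the limit of > 50000 nM in this assay, at which 2 of the 3 values shown sit.

Which of the three chlorine atoms matters remains open. So does the effect of an amine or a carboxylic acid on this phenyl ring.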